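The source may hold more compounds than are shown below. What is called first, only, known or untested is meant among the compounds shown, and "the series" means these compounds.

Measured compounds:
- compound 1 `O=C(CCCCCNC(=O)c1cc(-c2ccc(F)cc2)[nH]n1)NO`: 29 nM in an assay on cells for inhibition of protein deacetylase HDAC6 (Homo sapiens), read by fluorescence, with stated times of 15 min and 60 min; a lower number here means a stronger inhibitor, a higher number a weaker inhibitor
- compound 2 `CCCc1cc(-c2ccc(F)cc2)n(Cc2ccc(C(=O)NO)cc2)n1`: 167 nM
- compound 3 `O=C(CCCCCCNC(=O)c1cc(-c2ccc(F)cc2)[nH]n1)NO`: 22 nM

Compound 2 gives the highest of the three numbers in this assay; compound 1 stands nearest to it, and compound 3 furthest, both gaps beyond the scatter. For the measured compounds named here, the one step among the measured compounds, a 1.3-fold lower number from compound 1 to compound 3 (0.12 log units; within the scatter), concerns the hydroxamate-bearing chain of compounds 1 and 3 and lies within the scatter.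

The unmeasured compound 4 `Cc1cc(-c2ccc(F)cc2)n(Cc2ccc(C(=O)NO)cc2)n1` differs from compound 2 by hydrogen in place of ethyl on a saturated chain carbon bound to an aromatic carbon. Going by the values given here, no measured step touches this part of the structure: compounds 1 and 3 carry no such alkyl group on their core, and the step between them alters a different chain. Among the compounds with values here, the only guidance the data give is that a change of chain length elsewhere, a 1.3-fold lower number from compound 1 to compound 3 (0.12 log units; within the scatter), left the number essentially where it was. On that slim basis the shortening is expected to move compound 2 to compound 4 by little, with no direction favoured beyond the scatter; the step of a 1.2-fold higher number from compound 2 to compound 4 (0.08 log units; within the scatter) is therefore estimated to stay small. Compound 4 is expected to give about 200 nM in this assay, within a range from 80 nM to 500 nM.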

Compound 4, half-maximal inhibitory concentration: 20 nM
For compound 4 the middle estimate is 10-fold (1.00 log units) above the measured one; the measured number lies below the stated range.
By their numbers in this assay, from the lowest: compounds 4, 3 and 1 (each within the scatter of the next); then compound 2.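

In this assay, for the compounds shown here, the change of propyl to methyl is the first in this set to touch the saturated chain carbon bound to an aromatic carbon, and the step is an 8.4-fold lower number from compound 2 to compound 4 (0.92 log units; beyond the scatter), so the group at this place clearly bears on the number. Going by these compounds alone, the only earlier step, a 1.3-fold lower number from compound 1 to compound 3 (0.12 log units; within the scatter), altered the hydroxamate-bearing chain and stayed within the scatter, and the present result shows that such insensitivity to chain length there does not carry over to this alkyl group on the core. No measurement shown here accounts for the size of this step.

The compounds shown leave open how the number runs through the ethyl group as an intermediate, and whether a butyl chain at this place would raise it further or a hydroxymethyl group would keep it near that of compound 4. They also leave open whether an alkyl group placed on the core of compound 1 or compound 3, which carry none, would respond in the same way.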